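A Hydroxypropyl Chain in Place of the Dioxolane

A few compounds are considered here, and "the series" means these few. Any claim that something is new, unique, unknown or untested is made for them only; others in the source may bear on it.

Compound 3 `Cn1c(Cc2nn(CCC3OCCO3)c(=O)c3ccccc23)nnc1SCC(=O)Nc1ccc(Cl)cc1Cl` was tested in an assay on 32D cells for inhibition of interleukin-15 (Mus musculus), read by resazurin assay, with stated times of 30 min and 2.5 days, in the presence of a further agent that is not named here; on this read-out lower numbers stand for stronger inhibition and higher numbers for weaker inhibition. For compound 3 the assay reports only a limit, > 30000 nM. Compound 3 stands at the limit of > 30000 nM in this assay, at which 2 of the 3 values shown sit. Compound 1 `CCOC(CCn1c(Cc2nn(C)c(=O)c3ccccc23)nnc1SCC(=O)Nc1ccc(Cl)cc1Cl)OCC` likewise gives only a limit, > 30000 nM, in this assay. Among the measured compounds shown here, compound 2 `CN(C)CCCn1c(Cc2nn(C)c(=O)c3ccccc23)nnc1SCCCCCCCC(=O)Nc1ccc(Cl)cc1Cl` gives 5500 nM in this assay, but it differs from the other compounds in several places at once, so no single step can be drawn from it. Compound 4 `Cn1c(Cc2nn(CCCO)c(=O)c3ccccc23)nnc1SCC(=O)Nc1ccc(Cl)cc1Cl` differs from compound 3 by hydroxymethyl in place of 1,3-dioxolan-2-yl on a saturated chain carbon, two bonds along the chain from an aromatic nitrogen. For the measured compounds named here, no measured step of this kind exists in the set, so the account expects no change beyond the scatter, with compound 4 most likely remaining at the limit. Compound 4 is estimated at 30000 nM, with a range from 8000 nM to 100000 nM. The expected step is a number no higher from compound 3 to compound 4 (the limit leaves the size open).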

Compound 4, half-maximal inhibitory concentration: > 30000 nM
Compound 4: only a limit was reported (the forecaster's own chance of this, stated with the estimate: 60%); the middle value sits exactly at the limit.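

Compound 3 and compound 4 both give only a limit in this assay, and no step can be read between them. The compounds shown leave open whether hydroxymethyl in place of 1,3-dioxolan-2-yl changes inhibition at all.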